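Trimethoxyphenyl for hydroxyphenyl on the saturated ring carbon

The source may hold more compounds than are shown below. What is called first, only, known or untested is meant among the compounds shown, and "the series" means these compounds.

Compound 1 `Cc1cc(O)c(C2=NN(c3ccc(S(N)(=O)=O)cc3)C(c3ccccc3O)C2)cc1Cl`: 59000 nM
Compound 2 `Cc1cc(O)c(C2=NN(c3ccc(S(N)(=O)=O)cc3)C(c3ccccc3Cl)C2)cc1Cl`: > 100000 nM

In a functional assay on UACC-257 cells (Homo sapiens) for antiproliferative activity, with a stated time of 48 h (a lower number here means that less compound is tolerated, a higher number that more compound is tolerated), compound 1 gives 59000 nM. Compound 2 is reported only at a limit of this assay, > 100000 nM. Compound 1 thus stands as the only actual number shown, the other value being a limit (the limit of > 100000 nM in this assay, at which 1 of the 2 values shown sits). For the measured compounds named here, the one measured step, an at least 1.6-fold higher number from compound 1 to compound 2 (0.22 log units; that floor lies within the scatter), concerns chloro in place of hydroxy on an aromatic carbon and lies at a floor within the scatter.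

Compound 3 `COc1ccc(C2CC(c3cc(Cl)c(C)cc3O)=NN2c2ccc(S(N)(=O)=O)cc2)c(OC)c1OC` differs from compound 1 by 2,3,4-trimethoxyphenyl in place of 2-hydroxyphenyl on a saturated ring carbon. Going by the values given here, no measured step touches this position, so the measured step gives no direction for this change. Compound 3 is therefore expected to sit near compound 1, as a step of a 1.0-fold higher number from compound 1 to compound 3 (0.01 log units; within the scatter); the estimate for compound 3 is 60000 nM, within 20000 nM to 100000 nM.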

Compound 3, concentration lethal to 50% of the cells: > 100000 nM
Compound 3: only a limit was reported (the forecaster's own chance of this, stated with the estimate: 35%); middle value at least 1.6-fold (0.22 log units) from the limit.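

In this assay, 2,3,4-trimethoxyphenyl in place of 2-hydroxyphenyl on a saturated ring carbon gives an at least 1.6-fold higher number from compound 1 to compound 3 (0.22 log units; that floor lies within the scatter). For the compounds shown here, compound 3 and compound 2 both sit at a limit of the assay rather than at a number, so compound 1 remains the only one with an actual value: the limit of > 100000 nM in this assay, at which 2 of the 3 values shown sit. Both floors point the same way from compound 1, but each lies within the scatter, and the step between compound 2 and compound 3 cannot be read because both are limits.

As far as these compounds go, how far compound 2 and compound 3 lie past that limit remains open. Also open, from the compounds shown here alone, is whether a 2-aminophenyl or a 2-carboxyphenyl group on the same saturated ring carbon would give a number on the scale of compound 1 or another limit.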